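The source may report more compounds than this note shows. Statements on the series, on what has been measured and on what is new or still open speak of the compounds shown alone.

Of the compounds shown here, two built on the same core have been tested in a functional assay on HGC-27 cells (Homo sapiens) for inhibition, read by MTT assay, with a stated time of 72 h; a higher number here means a weaker inhibitor, a lower number a stronger inhibitor. Compound 1, `Cc1nc2nc(SCc3ccc(Cl)cc3)nn2c(N2CC[C@@H](C)[C@@H](N(C)c3ncnc4[nH]ccc34)C2)c1C`, reaches only the limit of > 100000 nM in this assay, which marks the edge of the method rather than a measured number. Compound 2, `Cc1cc(N2CC[C@@H](C)[C@@H](N(C)c3ncnc4[nH]ccc34)C2)n2nc(SCCc3ccccc3)nc2n1`, gives 11800 nM in this assay. For the measured compounds named here, that is the only true number among the two, so compound 2 stands on its own as the point of reference, while the other entry is a limit (the limit of > 100000 nM in this assay, at which 1 of the 2 values shown sits).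

Compound 3, `Cc1cc(N2CC[C@@H](C)[C@@H](N(C)c3ncnc4[nH]ccc34)C2)n2nc(SCCCc3ccccc3)nc2n1`, has not yet been measured. It differs from compound 2 in a single place: benzyl in place of phenyl on a saturated chain carbon, two bonds along the chain from a sulfur. Read from the sulfur outward, phenethylsulfanyl becomes (3-phenylpropyl)sulfanyl.

Going by the values given here, no pair of measured compounds differs only in this way, so there is nothing here to anchor the size or direction of such a step. The step of a 1.0-fold higher number from compound 2 to compound 3 (0.01 log units; within the scatter) is therefore expected to be none beyond the usual scatter. Compound 3 is expected to give about 12000 nM in this assay, with a likely range from 4000 nM to 40000 nM.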

Compound 3, half-maximal inhibitory concentration: > 100000 nM
Compound 3: only a limit was reported; the forecaster's own chance of this, stated with the estimate: 15%; middle value at least 8.3-fold (0.92 log units) from the limit.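

Going from phenethylsulfanyl to (3-phenylpropyl)sulfanyl, with benzyl in place of phenyl on a saturated chain carbon, gives an at least 8.4-fold higher number from compound 2 to compound 3 (0.92 log units; beyond the scatter) in this assay. The earlier compounds shown here offered no such pair, and this one shows that the length of the chain carrying the phenyl ring on the sulfur matters here, since even this small extension moves the result beyond the scatter, in the direction of a weaker inhibitor. The full size of the step remains unknown, since compound 3 reaches only a limit, one that now accounts for most of the results: the limit of > 100000 nM in this assay, at which 2 of the 3 values shown sit.

What the compounds shown leave open is whether this position can give anything better than compound 2, which stands at 11800 nM, as only one change in chain length can be read here. A shorter chain such as benzylsulfanyl on the core of compound 2, or a chain ending in an amine or a carboxylic acid instead of the phenyl ring, could show whether the loss continues in one direction or is specific to the 3-phenylpropyl group.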